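This account rests on a few compounds, and the source may have more. Where it says the series, first, only, none or still open, it means among the compounds named here.

Measured compounds:
compound 1, `O=C(Nc1cc(C(F)(F)F)cc(C(F)(F)F)c1)c1ccccc1`: "not determined" (no result reported)
compound 2, `O=C(Nc1cc(C(F)(F)F)cc(C(F)(F)F)c1)c1cc(Cl)cc(Cl)c1O`: > 60000 nM

In an ADME assay on cells (Macrophage, Mus musculus) for cytotoxicity, read by resazurin assay, with a stated time of 3 days (a higher number here means a weaker inhibitor, a lower number a stronger inhibitor), compound 1 gives "not determined" (no result reported), so no number is on record for it. In this assay compound 2 gives > 60000 nM; this is a limit of the assay, not a number. Among the compounds with values here, the only value shown is therefore (the limit of > 60000 nM in this assay, at which 1 of the 2 values shown sits), and compound 1 cannot be placed on a scale of numbers at all. Compound 3, `O=C(Nc1cc(C(F)(F)F)cc(C(F)(F)F)c1)c1ccccc1Cl`, differs from compound 1 by chloro in place of hydrogen on an aromatic carbon. Within the data shown here, no measured pair shows how such a change moves the read-out here. Because compound 2 gives > 60000 nM, the expectation for the step from compound 1 to compound 3 in this assay is none beyond the scatter, with compound 3 likely to reach only a limit as well. Compound 3 is expected to give 60000 nM, within a range from 20000 nM to 100000 nM.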

Compound 3, half-maximal inhibitory concentration: > 1700 nM
Compound 3 was reported as a limit; the forecaster's own chance of this, stated with the estimate: 80%; the middle value does not contradict the limit.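

Within the data shown here, no step from compound 1 to compound 3 can be read in this assay. Compound 3 gives > 1700 nM, which is a limit of the assay and not a number. The compounds shown leave open whether, and how far, chloro in place of hydrogen moves the read-out.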